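Fluoro in place of cyano: a step from a limit

The source may hold more compounds than are shown below. What is called first, only, known or untested is meant among the compounds shown, and "the series" means these compounds.

Compound 1 `COc1ccc(-n2cc(CCCOS(=O)(=O)c3ccc(C)cc3)nn2)cc1`: 74600 nM
Compound 2 `Cc1ccc(S(=O)(=O)OCCCc2cn(-c3cccc(C#N)c3)nn2)cc1`: > 100000 nM, a limit

In a functional assay on A549 cells (Homo sapiens) for cytotoxicity, read by MTT assay, with a stated time of 48 h (on this read-out lower numbers stand for stronger inhibition and higher numbers for weaker inhibition), compound 1 gives 74600 nM. Compound 2 reads > 100000 nM, which is a limit of the assay and not a number. Among the measured compounds shown here, of the values so far, the record shows (the limit of > 100000 nM in this assay, at which 1 of the 2 values shown sits).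

Compound 3 `Cc1ccc(S(=O)(=O)OCCCc2cn(-c3cccc(F)c3)nn2)cc1` differs from compound 2 by fluoro in place of cyano on an aromatic carbon. For the measured compounds named here, the one measured step, an at least 1.3-fold higher number from compound 1 to compound 2 (0.12 log units; that floor lies within the scatter), is a floor and bears only loosely on this change, as it concerns a different swap. On that step, only a small move is expected in this assay, towards a slightly lower number or none beyond the scatter. The estimated step is an at least 1.1-fold lower number from compound 2 to compound 3 (0.04 log units; that floor lies within the scatter). Compound 3 is therefore estimated at 90000 nM, with an expected range from 40000 nM to 180000 nM.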

Compound 3, half-maximal inhibitory concentration: > 100000 nM
Compound 3: no number, only a limit; the forecaster's own chance of this, stated with the estimate: 50%; at least 1.1-fold (0.04 log units) between middle value and limit.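

Compound 3, with 3-fluorophenyl in place of 3-cyanophenyl, gives > 100000 nM in this assay, which is a limit of the assay and not a number. Compound 2 is also a limit, so the step between these two cannot be read, and the swap of cyano for fluoro at this position has no measurable size here. The only readable comparison is an at least 1.3-fold higher number from compound 1 to compound 3 (0.12 log units; that floor lies within the scatter), and the record now stands thus: the limit of > 100000 nM in this assay, at which 2 of the 3 values shown sit.

On these data alone, what remains open is whether cyano and fluoro differ at all at this position, since neither compound gives a number. The compounds shown also leave open how an amine or a carboxylic acid in this place would read in this assay, and whether either would bring a number back within the range of the assay.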